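Trimming an Aryl Group to Methyl on a Fused Core

The source may report more compounds than this note shows. Statements on the series, on what has been measured and on what is new or still open speak of the compounds shown alone.

Measured compounds:
compound 1, `Cc1nc2c3ccccc3ccc2c2nc3c(ccc4ccccc43)c(-c3ccccc3S)c12`: 158 ug/mL
compound 2, `Cc1ccc(-c2c3ccc4ccccc4c3nc3c2c(C)nc2c4ccccc4ccc32)cc1`: 192 ug/mL

In a functional assay, with a stated time of 90 s (on this read-out lower numbers stand for stronger inhibition and higher numbers for weaker inhibition), compound 2 gives 192 ug/mL, the highest of the two numbers, while compound 1 gives 158 ug/mL. Among the compounds with values here, the single measured step, a 1.2-fold higher number from compound 1 to compound 2 (0.08 log units; within the scatter), swapped one aromatic group for another and stayed within the scatter. Compound 3, `Cc1nc2c3ccccc3ccc2c2nc3c(ccc4ccccc43)c(C)c12`, carries a smaller change: methyl in place of 4-methylphenyl on an aromatic carbon. Within the data shown here, no measured step removes a whole ring, so the direction is uncertain. Compound 3 is expected to show a 1.0-fold higher number from compound 2 to compound 3 (0.02 log units; within the scatter), with an estimate of 200 ug/mL in this assay and a range from 100 ug/mL to 400 ug/mL.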

Compound 3, half-maximal inhibitory concentration: 195 ug/mL
For compound 3 the middle estimate is 1.0-fold (0.01 log units) above the measured one, within the range that was stated.
By their numbers in this assay, from the lowest: compounds 1, 2 and 3 (each within the scatter of the next).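

In this assay, trimming 4-methylphenyl to methyl removes a whole aromatic ring from this carbon, yet the step is only a 1.0-fold higher number from compound 2 to compound 3 (0.01 log units; within the scatter). Replacing 2-sulfanylphenyl with methyl gives a 1.2-fold higher number from compound 1 to compound 3 (0.09 log units; within the scatter), so across these three compounds this read-out does not separate either aryl group from methyl. No measured evidence bears on why the numbers stay so close. From the compounds shown here alone, what remains open is whether an amine, a carboxylic acid or a longer chain on this carbon would give a step beyond the scatter.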